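Swapping an indole for a hydroxynaphthalene on a hydrazone

This account rests on a few compounds, and the source may have more. Where it says the series, first, only, none or still open, it means among the compounds named here.

Measured so far:
Compound 1, `C#CCSc1nc(N/N=C/c2c(O)ccc3ccccc23)c2nnn(Cc3ccccc3)c2n1`: 8970 nM
Compound 2, `CCCSc1nc(N/N=C/c2c[nH]c3ccccc23)c2nnn(Cc3ccccc3)c2n1`: 9010 nM

In a functional assay on MCF7 cells (Homo sapiens) for antiproliferative activity, read by MTT assay, with a stated time of 72 h (on this read-out lower numbers stand for stronger inhibition and higher numbers for weaker inhibition), compound 1 gives 8970 nM. Compound 2, measured the same way, gives 9010 nM. Going by the values given here, these two numbers sit essentially on top of each other, so compound 2 cannot be said to stand above or below compound 1; with only two compounds measured, it simply shares the one level seen so far.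

Compound 3, `CCCSc1nc(N/N=C/c2c(O)ccc3ccccc23)c2nnn(Cc3ccccc3)c2n1`, has not been measured yet. It is compound 2 with one change: 2-hydroxynaphthalen-1-yl in place of 1H-indol-3-yl on a carbon with a double bond to nitrogen. This brings in the same hydrazone-linked ring system that compound 1 carries, while keeping the propyl thioether of compound 2. Both measured compounds, despite their different ring systems, landed at the same level, so no step beyond the scatter is expected from compound 2 to compound 3, and the expected step of a 1.0-fold lower number from compound 2 to compound 3 (0.00 log units; within the scatter) reflects that. Compound 3 is therefore estimated at 9000 nM, within a range from 4000 nM to 20000 nM.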

Compound 3, half-maximal inhibitory concentration: 6400 nM
For compound 3 the middle estimate is 1.4-fold (0.15 log units) above the measured one, and the stated range covers the measured number.
By their numbers in this assay, from the lowest: compounds 3, 1 and 2 (each within the scatter of the next).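

In this assay, putting 2-hydroxynaphthalen-1-yl in place of 1H-indol-3-yl on a carbon with a double bond to nitrogen gives a 1.4-fold lower number from compound 2 to compound 3 (0.15 log units; within the scatter). Going by these compounds alone, compound 1 and compound 2 differ in two places, so this is the first reading of the ring change alone, and the same holds for the chain, where ethyl in place of ethynyl on a saturated chain carbon bound to a sulfur gives a 1.4-fold lower number from compound 1 to compound 3 (0.15 log units; within the scatter). Neither single change separates its pair of compounds on this read-out.

Going by these compounds, whether an amine or a carboxylic acid on the ring, or a longer chain on the sulfur, would give a step beyond the scatter stays open. No other data here bear on these results.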